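Bromo for Chloro: From Compound 2 to Compound 4

The source may hold more compounds than are shown below. What is called first, only, known or untested is meant among the compounds shown, and "the series" means these compounds.

Of the compounds shown here, three on one shared core have been measured in an ADME assay on L929 cells (Mus musculus) for cytotoxicity, read by MTT assay, with a stated time of 72 h; on this read-out lower numbers stand for higher toxicity in this test and higher numbers for lower toxicity in this test. Compound 1 `CCOC(=O)c1[nH]c(=O)c(C#N)cc1C(=O)c1ccccc1` gives 465000 nM. Compound 2 `CCOC(=O)c1[nH]c(=O)c(C#N)cc1C(=O)c1ccc(Cl)cc1` gives 218000 nM, and compound 3 `CCOC(=O)c1[nH]c(=O)c(C#N)cc1C(=O)c1ccc([N+](=O)[O-])cc1` gives 213000 nM. Compound 2 stands second highest of the three numbers: a 2.1-fold lower number from compound 1 to compound 2 (0.33 log units; beyond the scatter), whereas a 1.0-fold lower number from compound 2 to compound 3 (0.01 log units; within the scatter), so compound 2 and compound 3 lie within the scatter of each other.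

Compound 4 `CCOC(=O)c1[nH]c(=O)c(C#N)cc1C(=O)c1ccc(Br)cc1` has not yet been measured in this assay. It differs from compound 2 in one place: bromo in place of chloro on an aromatic carbon. Among the compounds with values here, two measured steps bear on this change. The step of a 2.1-fold lower number from compound 1 to compound 2 (0.33 log units; beyond the scatter) shows that putting a group on this aromatic carbon moved the number modestly. The step of a 1.0-fold lower number from compound 2 to compound 3 (0.01 log units; within the scatter) shows that exchanging one group for another on the same aromatic carbon left the number within the scatter. Because a 1.0-fold lower number from compound 2 to compound 3 (0.01 log units; within the scatter) involved no more than an exchange of one group for another on this aromatic carbon and compound 4 again makes such an exchange there, the expected step is a 1.1-fold lower number from compound 2 to compound 4 (0.04 log units; within the scatter). For compound 4 in this assay the estimate is 200000 nM, with a range from 100000 nM to 420000 nM.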

Compound 4, half-maximal cytotoxic concentration: 242000 nM
For compound 4 the middle estimate is 1.2-fold (0.08 log units) below the measured one; the measured number falls inside the stated range.
By their numbers in this assay, from the lowest: compounds 3, 2, 4 and 1 (each within the scatter of the next, the first and the last beyond it).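

In this assay the exchange of one group for another on this aromatic carbon again stays within the scatter, with a 1.1-fold higher number from compound 2 to compound 4 (0.05 log units; within the scatter) and a 1.1-fold higher number from compound 3 to compound 4 (0.06 log units; within the scatter) as the two new steps, so chloro, nitro and bromo cannot be told apart here. New is that a group on this carbon need not clear the scatter against hydrogen: a 1.9-fold lower number from compound 1 to compound 4 (0.28 log units; within the scatter) stands within it, while a 2.1-fold lower number from compound 1 to compound 2 (0.33 log units; beyond the scatter) and a 2.2-fold lower number from compound 1 to compound 3 (0.34 log units; beyond the scatter) stand just beyond it, so the effect of adding a group lies near the edge of the scatter. No measurement shown here explains these numbers.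

Open is whether a different kind of group on this aromatic carbon, such as an amine or a carboxylic acid, would stay within the scatter of these compounds. Also open, from the compounds shown here alone, is what a longer chain in place of the ethyl of the ester would do.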